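The source may report more compounds than this note shows. Statements on the series, on what has been measured and on what is new or still open speak of the compounds shown alone.

In an assay on isolated protein for inhibition of Equilibrative nucleoside transporter 1 (Homo sapiens) (on this read-out lower numbers stand for stronger inhibition and higher numbers for weaker inhibition), compound 1 `OC[C@H]1O[C@@H](n2cnc3c(SCc4cccc(Cl)c4)ncnc32)[C@H](O)[C@@H]1O` gives 18.2 nM, while compound 2 `N#Cc1cccc(CSc2ncnc3c2ncn3[C@@H]2O[C@H](CO)[C@@H](O)[C@H]2O)c1` gives 36.3 nM, the higher of the two numbers, with a 2.0-fold higher number from compound 1 to compound 2 (0.30 log units; within the scatter). Compound 3 `O=[N+]([O-])c1cccc(CSc2ncnc3c2ncn3[C@@H]2O[C@H](CO)[C@@H](O)[C@H]2O)c1` differs from compound 2 in one place: nitro in place of cyano on an aromatic carbon. Within the data shown here, the one measured step that bears on this change, at the same aromatic carbon, stayed within the scatter, so no step beyond the scatter is expected here, and a step of a 1.1-fold higher number from compound 2 to compound 3 (0.04 log units; within the scatter) is estimated. Compound 3 is therefore expected to give about 40 nM in this assay, within a range from 15 nM to 110 nM.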

Compound 3, inhibition constant: 1.78 nM
Beside the measured number, compound 3's estimate is 22-fold (1.35 log units) above it; measured number outside the range, below it.
By their numbers in this assay, from the lowest: compound 3; then compounds 1 and 2 (each within the scatter of the next).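

The position on this aromatic ring, meta to a large group, is more sensitive than the earlier pair suggested: nitro in place of cyano gives a 20-fold lower number from compound 2 to compound 3 (1.31 log units; beyond the scatter), and nitro in place of chloro gives a 10-fold lower number from compound 1 to compound 3 (1.01 log units; beyond the scatter). Cyano and chloro stayed within the scatter of each other, so nitro alone stands apart among these three groups. No measurement shown here accounts for this difference. On these data alone, it remains open whether an amine or a carboxylic acid at this place would give a similarly low number, and whether nitro would keep its advantage elsewhere on the ring.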